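Replacing (piperidin-4-yl)methyl with tert-butyl

The source may report more compounds than this note shows. Statements on the series, on what has been measured and on what is new or still open speak of the compounds shown alone.

Measured in a functional assay on HCT-116 cells (Homo sapiens) for antiproliferative activity, with a stated time of 72 h; a lower number here means a stronger inhibitor, a higher number a weaker inhibitor:
compound 1 `CC(C)(CO)Cn1nc(-c2c[nH]c3ccccc23)c2c(N)ncnc21`: 13400 nM
compound 2 `Nc1ncnc2c1c(-c1c[nH]c3ccccc13)nn2CC1CCNCC1`: > 100000 nM

For compound 2, the reading > 100000 nM is a limit and not a number.

Compound 3 `CC(C)(C)n1nc(-c2c[nH]c3ccccc23)c2c(N)ncnc21` carries tert-butyl in place of (piperidin-4-yl)methyl on an aromatic nitrogen. Going by the values given here, the one measured step that bears on this is an at least 7.4-fold higher number from compound 1 to compound 2 (0.87 log units; beyond the scatter), which is beyond the scatter and introduced piperidin-4-yl. Compound 3 loses that ring, so a lower number is expected in this assay, with an expected step of an at least 8.3-fold lower number from compound 2 to compound 3 (0.92 log units; beyond the scatter). The estimate for compound 3 is 12000 nM, with a range of 3000 nM to 50000 nM.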

Compound 3, half-maximal inhibitory concentration: 2500 nM
Beside the measured number, compound 3's estimate is 4.8-fold (0.68 log units) above it; the whole stated range lies above it.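

Tert-butyl on the aromatic nitrogen gives the lowest number of the three in this assay, and a compact group with no ring or hydroxyl now stands as the best fit at this position, with an at least 40-fold lower number from compound 2 to compound 3 (1.60 log units; beyond the scatter) and a 5.4-fold lower number from compound 1 to compound 3 (0.73 log units; beyond the scatter). Compound 2 carries a limit and not a number, so the first of these steps gives only a floor for its size: the limit of > 100000 nM in this assay, at which 1 of the 3 values shown sits.

Still open, going by these compounds, is whether isopropyl or cyclopropyl on the same nitrogen would hold or lower the number. Also open, on these data alone, is whether a cyclohexylmethyl group, lacking the ring amine, would separate the effect of that amine from that of the ring.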